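This account rests on a few compounds, and the source may have more. Where it says the series, first, only, none or still open, it means among the compounds named here.

Compound 3 `CN(C)S(=O)(=O)c1ccc(CNC(=O)c2nc(-c3ccc(F)cc3)n(CC[C@@H](O)C[C@@H](O)CC(=O)O)c2C2CC2)cc1` stands at the edge of what a functional assay on L6 cells (Rattus norvegicus) for inhibition, read by scintillation counting, with a stated time of 3 h (on this read-out higher numbers stand for weaker inhibition and lower numbers for stronger inhibition), can report: in this assay compound 3 gives > 100000 nM, which is a limit of the assay and not a number (the limit of > 100000 nM in this assay, at which 1 of the 3 values shown sits). Compound 4 `O=C(O)C[C@H](O)C[C@H](O)CCn1c(-c2ccc(F)cc2)nc(C(=O)NCc2ccccc2)c1C1CC1` differs from it by hydrogen in place of dimethylsulfamoyl on an aromatic carbon. For the measured compounds named here, two measured steps bear on this change. Compound 1 `Cc1ccc(CNC(=O)c2nc(-c3ccc(F)cc3)n(CC[C@@H](O)C[C@@H](O)CC(=O)O)c2C2CC2)cc1` gives 178 nM in this assay, and an at least 560-fold higher number from compound 1 to compound 3 (2.74 log units; beyond the scatter). Compound 2 `O=C(O)C[C@H](O)C[C@H](O)CCn1c(-c2ccc(F)cc2)nc(C(=O)NCc2ccccc2F)c1C1CC1` gives 27200 nM, and an at least 3.6-fold higher number from compound 2 to compound 3 (0.56 log units; beyond the scatter). Removing the dimethylsulfamoyl should therefore lower the number considerably, although the group left behind still matters, because a 150-fold higher number from compound 1 to compound 2 (2.18 log units; beyond the scatter). Compound 4 is expected to give 1000 nM, within 150 nM to 8000 nM, an expected step of an at least 100-fold lower number from compound 3 to compound 4 (2.00 log units; beyond the scatter).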

Compound 4, half-maximal inhibitory concentration: 632 nM
Compound 4: the middle estimate sits 1.6-fold (0.20 log units) above what was measured; measured number inside the range.
By their numbers in this assay, from the lowest: compound 1; then compound 4; then compound 2. At a limit, above all of these: compound 3.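

Against the plain phenyl of compound 4, a reference the earlier compounds lacked, the methyl of compound 1 is the only group shown that goes with stronger inhibition in this assay: a 3.6-fold higher number from compound 1 to compound 4 (0.55 log units; beyond the scatter). The fluoro and the dimethylsulfamoyl each go with much weaker inhibition, with a 43-fold lower number from compound 2 to compound 4 (1.63 log units; beyond the scatter) and an at least 150-fold lower number from compound 3 to compound 4 (2.19 log units; beyond the scatter), so neither loss can be explained by the missing methyl alone. Compound 3 gives a limit and not a number: the limit of > 100000 nM in this assay, at which 1 of the 4 values shown sits.

Going by these compounds, whether a larger group such as ethyl or methoxy would match the methyl stays open. So does whether a 4-fluorophenyl would carry the same cost as the 2-fluorophenyl of compound 2.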